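The source may report more compounds than this note shows. Statements on the series, on what has been measured and on what is new or still open speak of the compounds shown alone.

In an ADME assay on HepG2 cells (Homo sapiens) for cytotoxicity, with a stated time of 72 h (on this read-out lower numbers stand for an effect already at smaller amounts and higher numbers for an effect only at larger amounts of compound), compound 1 `Cc1cc(NC(=O)Nc2ccccc2OC(F)(F)F)c2ccccc2n1` reads > 25000 nM and this is only a limit of the assay. Compound 2 `CC(=O)c1ccc(NC(=O)Nc2cc(C)nc3ccccc23)cc1` gives an actual number of 19000 nM in the same test. Compound 3 `Cc1cc(NC(=O)Nc2cccc([N+](=O)[O-])c2)c2ccccc2n1` reads > 25000 nM and this too is only a limit, so it stands at the limit of > 25000 nM in this assay, at which 2 of the 3 values shown sit, without a number of its own. Compound 4 `Cc1cc(NC(=O)Nc2cccc(C(N)=O)c2)c2ccccc2n1` differs from it in one place carbamoyl in place of nitro on an aromatic carbon with carbamoyl in place of nitro on an aromatic carbon. For the measured compounds named here, no measured pair shows this swap, and no step beyond the usual scatter is expected. The estimated a number no higher from compound 3 to compound 4 (the limit leaves the size open) is small. For compound 4 the expected value is 25000 nM with an estimated range from 12000 nM to 50000 nM and a good chance of another limit.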

Compound 4, half-maximal effective concentration: > 25000 nM
Compound 4: a limit, no number; the forecaster's own chance of this, stated with the estimate: 65%; the middle value lies on the limit itself.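

Compound 3 and compound 4 both stop at a limit of the assay rather than a number, so no step can be read between them. As far as these compounds go, whether carbamoyl in place of nitro shifts the read-out in this assay at all stays open.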